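The source may hold more compounds than are shown below. What is called first, only, known or untested is meant among the compounds shown, and "the series" means these compounds.

Compound 1 `COc1ccc(-c2ccc(-c3ccc(-c4nc5ccccc5[nH]4)cc3)cc2)cc1` is the starting point of this short series. In a functional assay on ZR-75-1 cells (Homo sapiens) for inhibition, read by sulforhodamine B assay (a higher number here means a weaker inhibitor of growth, a lower number a stronger inhibitor of growth), compound 1 gives 35100 nM. Compound 2 `COc1ccc(-c2ccc(-c3ccc(-c4nc5ccccc5[nH]4)cc3)cc2)cc1OC` carries a single change relative to compound 1: methoxy in place of hydrogen on an aromatic carbon. That change produced a step of a 1.1-fold higher number from compound 1 to compound 2 (0.05 log units; within the scatter), and in this assay compound 2 gives 39700 nM. Compound 3 `COc1ccc(-c2ccc(-c3ccc(-c4nc5c(O)cccc5[nH]4)cc3)cc2)cc1OC` adds a hydroxy group on the shared core, and the step was a 19-fold lower number from compound 2 to compound 3 (1.27 log units; beyond the scatter); in this assay compound 3 gives 2110 nM. The difference between the cores of compound 1 and compound 3 is not broken down here.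

Compound 4 `COc1cc(-c2ccc(-c3ccc(-c4nc5c(O)cccc5[nH]4)cc3)cc2)cc(OC)c1OC` has not yet been measured. It differs from compound 3 in one place: methoxy in place of hydrogen on an aromatic carbon. For the measured compounds named here, this is the same kind of change as the one between compound 1 and compound 2, though the surroundings are not identical: in compound 4 the entering group is also meta to a methoxy group. Because the earlier step of a 1.1-fold higher number from compound 1 to compound 2 (0.05 log units; within the scatter) stayed within the scatter, the step from compound 3 to compound 4 is expected to be small as well, around a 1.2-fold higher number from compound 3 to compound 4 (0.07 log units; within the scatter). Compound 4 is therefore estimated at 2500 nM in this assay, with a likely range from 1000 nM to 7000 nM.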

Compound 4, concentration for 50% growth inhibition: 190 nM
For compound 4 the middle estimate is 13-fold (1.12 log units) above the measured one, and the stated range ends above it.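

The new methoxy group gave a large step, an 11-fold lower number from compound 3 to compound 4 (1.05 log units; beyond the scatter), and in this assay it does not match the step for the same kind of change on the earlier core: the same change on two cores in this assay, a 1.1-fold higher number (0.05 log units; within the scatter) from compound 1 to compound 2 and an 11-fold lower number (1.05 log units; beyond the scatter) from compound 3 to compound 4, 13-fold (1.10 log units) apart, beyond the scatter of two such steps

This shows that, in this series, the size of the step for this change does not carry over reliably from one core to another, so a near-silent result on one core gave no safe guide to the other. It does not show why the steps differ, since the two pairs differ both in the hydroxy group on the core of compound 3 and in the surroundings of the entering group, which in compound 4 is also meta to a methoxy group.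

The compounds shown leave open which of these two differences matters, and how the same change would behave on a further core. Also open, on these data alone, is whether an ethoxy group or an amine in the place of this methoxy group would give a step of similar size.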